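A Smaller Aromatic Ring on a Shared Core

This account rests on a few compounds, and the source may have more. Where it says the series, first, only, none or still open, it means among the compounds named here.

Of the compounds shown here, three have been measured in an in vitro assay on HEK385-7 cells for displacement of a labelled ligand from prostaglandin D2 receptor 2 (Homo sapiens); on this read-out higher numbers stand for weaker inhibition and lower numbers for stronger inhibition. Compound 1 `O=C(O)Cc1sc(CS(=O)(=O)c2ccc(Cl)cc2)nc1-c1ccc(Cl)cc1` gives 1500 nM, compound 2 `O=C(O)Cc1sc(C(c2ccccc2)c2ccc(F)c(F)c2)nc1-c1ccc(F)cc1` gives 10 nM, and compound 3 `N#Cc1ccc(-c2nc(C(c3ccc(F)cc3)c3ccc(F)cc3)sc2CC(=O)O)cc1` gives 150 nM. Compound 3 thus stands second highest of the three numbers, with compound 1 a higher number beyond the scatter and compound 2 a lower number beyond the scatter. Compound 4 `O=C(O)Cc1sc(C(c2ccc(F)cc2)c2ccc(F)cc2)nc1-c1ccoc1` has not yet been measured. It differs from compound 3 in one place: furan-3-yl in place of 4-cyanophenyl on an aromatic carbon. Within the data shown here, no measured pair differs by this change alone, so the step is open. With compound 3 at 150 nM as the only anchor, the step in this assay is expected to stay within the usual scatter, as a 1.5-fold lower number from compound 3 to compound 4 (0.18 log units; within the scatter). Compound 4 is therefore estimated at 100 nM, within a range of 25 nM to 500 nM.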

Compound 4, half-maximal inhibitory concentration: 14 nM
Beside the measured number, compound 4's estimate is 7.1-fold (0.85 log units) above it; the whole stated range lies above it.
By their numbers in this assay, from the lowest: compounds 2 and 4 (each within the scatter of the next); then compound 3; then compound 1.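

At this position, on the aromatic carbon next to the ring nitrogen, the group matters a great deal. In this assay, furan-3-yl in place of 4-cyanophenyl gives an 11-fold lower number from compound 3 to compound 4 (1.03 log units; beyond the scatter). A five-membered ring with 5 heavy atoms is thus well tolerated here, and the larger 4-cyanophenyl with 8 is not required for a low number.

Where an unsubstituted phenyl or a thiophen-3-yl group would fall at this position remains open, so the step cannot yet be assigned to the furan ring or to the loss of the nitrile. No measurement at hand explains the size of this step.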